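Moving the methyl group on the sulfonamide aryl ring

This account rests on a few compounds, and the source may have more. Where it says the series, first, only, none or still open, it means among the compounds named here.

Of the compounds shown here, three have been measured in an assay on isolated protein for inhibition of Nicotinamide phosphoribosyltransferase (Homo sapiens), read by WST assay, with stated times of 60 min, 5 min and 30 min, in the presence of a further agent that is not named here; a lower number here means a stronger inhibitor, a higher number a weaker inhibitor. Compound 1 `O=C(/C=C/c1cccnc1)NCCCc1ccc(S(=O)(=O)Nc2ccccc2)cc1` gives 5920 nM. Compound 2 `O=C(/C=C/c1cccnc1)NCCCCCCCc1ccc(S(=O)(=O)Nc2ccccc2)cc1`, which carries a longer chain between the amide nitrogen and the shared core, gives 16.4 nM. Compound 3 `Cc1ccc(NS(=O)(=O)c2cccc(CCCCCCNC(=O)/C=C/c3cccnc3)c2)cc1` gives 9.78 nM, the lowest number of the three; its gap to compound 2 lies within the usual scatter of repeated measurements, so the two cannot be told apart, while its gap to compound 1 lies far beyond it.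

Compound 4 `Cc1cccc(NS(=O)(=O)c2cccc(CCCCCCNC(=O)/C=C/c3cccnc3)c2)c1` has not yet been measured. It is built from the same atoms as compound 3, joined differently: 3-methylphenyl in place of 4-methylphenyl on a sulfonamide nitrogen. Only the place of the methyl group on the ring attached to the sulfonamide nitrogen moves; the chain, the amide and the pyridine part are untouched. Among the compounds with values here, no measured pair in this set shows what such a shift does, so there is nothing to draw on but the change itself.

The step from compound 3 to compound 4 is expected to be small, most likely within the scatter in either direction: a 1.3-fold higher number from compound 3 to compound 4 (0.12 log units; within the scatter). Compound 4 is therefore expected to give about 13 nM, somewhere between 4 nM and 45 nM.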

Compound 4, half-maximal inhibitory concentration: 12.3 nM
Beside the measured number, compound 4's estimate is 1.1-fold (0.02 log units) above it; low and high end bracket the measured number.
By their numbers in this assay, from the lowest: compounds 3, 4 and 2 (each within the scatter of the next); then compound 1.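

Within the data shown here, this pair is the first in the set to differ in one place only, so it gives the first direct reading of the ring on the sulfonamide nitrogen. In this assay, the change from 4-methylphenyl to 3-methylphenyl is a 1.3-fold higher number from compound 3 to compound 4 (0.10 log units; within the scatter), which means that compound 3 and compound 4 cannot be told apart and that this assay does not distinguish these two placements of the methyl group, at least with this chain, amide and pyridine part held fixed. No measurement shown here bears on why the shift leaves the two compounds indistinguishable.

Among these compounds, this single pair tests only one small carbon group moved on one ring, so it cannot show whether the methyl group matters at all, and what a plain phenyl ring on the sulfonamide nitrogen would give with this same chain remains open. Also open, from the compounds shown here alone, is whether the same tolerance would hold for a different group on this ring, such as a methoxy group, a chlorine atom, an amine or a carboxylic acid.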